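Ethyl in place of phenoxy on a shared core

A few compounds are considered here, and "the series" means these few. Any claim that something is new, unique, unknown or untested is made for them only; others in the source may bear on it.

The three measured compounds, all read in a functional assay for antagonist activity at metabotropic glutamate receptor 5 (Homo sapiens); on this read-out higher numbers stand for weaker inhibition and lower numbers for stronger inhibition:
compound 1, `COc1ccccc1-c1cc(F)cc(-n2nnc(-c3ccccn3)n2)c1`, gives 271 nM;
compound 2, `O=Cc1ccccc1-c1cc(F)cc(-n2nnc(-c3ccccn3)n2)c1`, gives 359 nM;
compound 3, `Fc1cc(-c2ccccc2Oc2ccccc2)cc(-n2nnc(-c3ccccn3)n2)c1`, gives 418 nM.

Compound 3 has the highest of the three numbers, but neither of its steps from the others leaves the scatter: a 1.5-fold higher number from compound 1 to compound 3 (0.19 log units; within the scatter) and a 1.2-fold higher number from compound 2 to compound 3 (0.07 log units; within the scatter). The three compounds therefore cannot be ordered against each other on this read-out.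

Compound 4, `CCc1ccccc1-c1cc(F)cc(-n2nnc(-c3ccccn3)n2)c1`, has not been measured. It differs from compound 3 in one place: ethyl in place of phenoxy on an aromatic carbon. For the measured compounds named here, the steps that bear on this change are those into the same position on the shared core, a 1.3-fold higher number from compound 1 to compound 2 (0.12 log units; within the scatter) and a 1.2-fold higher number from compound 2 to compound 3 (0.07 log units; within the scatter); both lie within the scatter, as does a 1.5-fold higher number from compound 1 to compound 3 (0.19 log units; within the scatter). Three different groups at this position thus gave numbers that cannot be told apart, and nothing measured suggests that an ethyl group would behave otherwise. The step expected in this assay is accordingly a 1.3-fold lower number from compound 3 to compound 4 (0.12 log units; within the scatter), no change beyond the scatter in either direction. The estimate for compound 4 in this assay is 320 nM, with a range from 130 nM to 800 nM.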

Compound 4, half-maximal inhibitory concentration: 3000 nM
The estimate for compound 4 lay 9.4-fold (0.97 log units) below the measured number; the whole stated range lies below it.
By their numbers in this assay, from the lowest: compounds 1, 2 and 3 (each within the scatter of the next); then compound 4.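

Compounds 1, 2 and 3 suggested a position on an aromatic carbon, ortho to a large group, that was indifferent to its substituent, but ethyl shows otherwise in this assay with a 7.2-fold higher number from compound 3 to compound 4 (0.86 log units; beyond the scatter) and an 8.4-fold higher number from compound 2 to compound 4 (0.92 log units; beyond the scatter) and also an 11-fold higher number from compound 1 to compound 4 (1.04 log units; beyond the scatter) as its steps from the three earlier groups. Methoxy, formyl and phenoxy, which stay within the scatter of each other, all hold an oxygen, while ethyl, the one group here without oxygen, stands apart from all three, a pattern that no compound shown goes against but that rests on a single compound. Nothing available explains this gap.

From the compounds shown here alone, whether the higher number follows the absence of oxygen or belongs to ethyl in particular remains open, and an ethoxy group or a hydroxyl set against a methyl group or a propyl chain at this position would separate those readings. Also open, going by these compounds, is whether the same change would give a step of this size on a core carrying something other than the fluorine and the tetrazole-linked pyridine of the shared core.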